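Replacing a methoxy with fluoro on compound 3

The source may report more compounds than this note shows. Statements on the series, on what has been measured and on what is new or still open speak of the compounds shown alone.

In a functional assay on A549 cells (Homo sapiens) for antiproliferative activity, read by MTT assay, with a stated time of 48 h (on this read-out higher numbers stand for weaker inhibition and lower numbers for stronger inhibition), compound 1 `COc1cc(-c2cccc3nc(-c4ccccc4)oc23)cc(OC)c1OC` gives 20300 nM, compound 2 `COc1cccc(-c2nc3cccc(-c4cc(OC)c(OC)c(OC)c4)c3o2)c1` gives 3500 nM and compound 3 `COc1ccc(-c2nc3cccc(-c4cc(OC)c(OC)c(OC)c4)c3o2)cc1OC` gives 2800 nM. Compound 3 cannot be separated from its nearest neighbour: a 1.3-fold lower number from compound 2 to compound 3 (0.10 log units; within the scatter). Its distance from the plain phenyl is clearer: a 7.3-fold lower number from compound 1 to compound 3 (0.86 log units; beyond the scatter).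

Compound 4 `COc1ccc(-c2nc3cccc(-c4cc(OC)c(OC)c(OC)c4)c3o2)cc1F` turns the 3,4-dimethoxyphenyl into 3-fluoro-4-methoxyphenyl, with fluoro in place of methoxy on an aromatic carbon, ortho to a methoxy group and meta to a large group: fluoro in place of methoxy on an aromatic carbon.

Going by the values given here, no measured compound carries fluoro, so the evidence is indirect. The first methoxy on the phenyl was worth a modest step, a 5.8-fold lower number from compound 1 to compound 2 (0.76 log units; beyond the scatter), while the second added nothing beyond the scatter, a 1.3-fold lower number from compound 2 to compound 3 (0.10 log units; within the scatter). Compound 4 keeps one methoxy, so losing the other should cost little. The expected change is small, a 1.4-fold higher number from compound 3 to compound 4 (0.15 log units; within the scatter), and stays within the scatter. For compound 4 the estimated value is 4000 nM, with an expected range from 1600 nM to 10000 nM.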

Compound 4, half-maximal inhibitory concentration: 1800 nM
Estimate against measurement, compound 4: 2.2-fold (0.35 log units) above, and the stated range covers the measured number.
By their numbers in this assay, from the lowest: compounds 4, 3 and 2 (each within the scatter of the next); then compound 1.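

In this assay, fluoro can take the place of methoxy here with no loss that can be read (a 1.6-fold lower number from compound 3 to compound 4 (0.19 log units; within the scatter)). The 3-fluoro-4-methoxyphenyl compound also stays within the scatter of the compound with a single methoxy (a 1.9-fold lower number from compound 2 to compound 4 (0.29 log units; within the scatter)), so a second methoxy on the phenyl is not required for this level of activity. It also holds the separation from the plain phenyl, which now counts as large (an 11-fold lower number from compound 1 to compound 4 (1.05 log units; beyond the scatter)). Nothing available explains why these two groups can stand in for each other at this place.

The compounds shown leave open whether chloro, hydroxy or an amine would serve equally well at this position. They also leave open whether fluoro would still be tolerated without the methoxy group on the same ring.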